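Expected Non-Toxicity of a 2-Methylphenyl Lactam Analogue

The source may hold more compounds than are shown below. What is called first, only, known or untested is meant among the compounds shown, and "the series" means these compounds.

The series rests on a shared core carrying a pyrrolidinone whose amide-type nitrogen bears a varying substituent. In a functional assay on HEK293 cells (Homo sapiens) for cytotoxicity (on this read-out lower numbers stand for higher toxicity in this test and higher numbers for lower toxicity in this test), compound 1 `COc1ccc([C@H]2CC(=O)N(C(C)=O)C2)cc1OC1CCCC1` gives > 10000 nM, which is a limit of the assay rather than a number. Compound 2 `COc1ccc([C@H]2CC(=O)N(c3ccccc3)C2)cc1OC1CCCC1` gives > 10000 nM in this assay, again a limit. Compound 3 `COc1ccc([C@H]2CC(=O)N(c3cc(N)cc(N)c3)C2)cc1OC1CCCC1` gives > 10000 nM, also a limit, so compound 3 stands only at the edge of what this assay can report, alongside the two other values. Because the limit of > 10000 nM in this assay, at which 3 of the 3 values shown sit, holds for every measured compound, the steps a step that the two limits leave unreadable from compound 1 to compound 2, a step that the two limits leave unreadable from compound 1 to compound 3 and a step that the two limits leave unreadable from compound 2 to compound 3 cannot be read in size or direction.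

Compound 4 `COc1ccc([C@H]2CC(=O)N(c3ccccc3C)C2)cc1OC1CCCC1` differs from compound 3 by a single exchange: 2-methylphenyl in place of 3,5-diaminophenyl on an amide-type nitrogen in a ring. For the measured compounds named here, no measured step gives a readable size for this kind of change, since all three neighbouring values are limits. The only inference available is that neither acetyl, phenyl nor 3,5-diaminophenyl on this nitrogen produced toxicity within the measurable window. Compound 4 is therefore expected to behave the same way, with an estimated value of 20000 nM spanning 8000 nM to 60000 nM. The step that the limit leaves unreadable from compound 3 to compound 4 is expected to be none beyond the scatter, most probably reported again as a limit.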

Compound 4, half-maximal cytotoxic concentration: > 10000 nM
Compound 4 ended at the assay's limit; the forecaster's own chance of this, stated with the estimate: 85%; the middle value lies beyond the limit too.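

The steps from compound 1, compound 2 and compound 3 to compound 4 cannot be read in size or direction, since all four compounds sit at the same limit of the assay: the limit of > 10000 nM in this assay, at which 4 of the 4 values shown sit.

The compounds shown leave open at what concentration any of them would become cytotoxic in this assay, and whether the substituent on the amide-type nitrogen in a ring alters that concentration.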